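Compound 4 Varies the Arylamino Group of Compound 1

The source may hold more compounds than are shown below. What is called first, only, known or untested is meant among the compounds shown, and "the series" means these compounds.

Compound 1 `Cc1cc(Cl)ccc1Nc1nc(C(F)(F)F)ccc1C(=O)N/N=C/c1ccc([N+](=O)[O-])cc1` is measured in a functional assay on NCI60 cells (Homo sapiens) for cytotoxicity, read by sulforhodamine B assay, with a stated time of 48 h (on this read-out higher numbers stand for weaker inhibition of growth and lower numbers for stronger inhibition of growth), where compound 1 gives 4680 nM. Two companions share its core and differ only in the aryl group attached to the carbon that is double-bonded to nitrogen. In this assay compound 2 `Cc1cc(Cl)ccc1Nc1nc(C(F)(F)F)ccc1C(=O)N/N=C/c1ccc(Cl)cc1` gives 7590 nM, and compound 3 `Cc1cc(Cl)ccc1Nc1nc(C(F)(F)F)ccc1C(=O)N/N=C/c1c(Cl)cccc1Cl` gives 11700 nM. Among the three, compound 1 has the lowest number: the step of a 1.6-fold higher number from compound 1 to compound 2 (0.21 log units; within the scatter) is within the scatter, while a 2.5-fold higher number from compound 1 to compound 3 (0.40 log units; beyond the scatter) is a modest step beyond it, and a 1.5-fold higher number from compound 2 to compound 3 (0.19 log units; within the scatter) is again within the scatter.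

Compound 4 `COc1ccc(Cl)cc1Nc1nc(C(F)(F)F)ccc1C(=O)N/N=C/c1ccc([N+](=O)[O-])cc1` keeps the 4-nitrophenyl group of compound 1 and alters the other end of the molecule: 5-chloro-2-methoxyphenyl in place of 4-chloro-2-methylphenyl on a nitrogen on an aromatic ring. Among the compounds with values here, none of the measured steps touches this part of the structure; all three vary the aryl group on the carbon double-bonded to nitrogen, and they span only a small range of numbers. Within the data shown here, no measured step therefore bears directly on the change from compound 1 to compound 4, and the expectation is a step no larger than the scatter in either direction, a 1.1-fold higher number from compound 1 to compound 4 (0.03 log units; within the scatter). Compound 4 is accordingly estimated at 5000 nM in this assay, with a range from 2000 nM to 13000 nM that is widened because the change lacks any precedent among the measured compounds.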

Compound 4, concentration for total growth inhibition: 8710 nM
The estimate for compound 4 lay 1.7-fold (0.24 log units) below the measured number; low and high end bracket the measured number.
By their numbers in this assay, from the lowest: compounds 1, 2, 4 and 3 (each within the scatter of the next, the first and the last beyond it).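

The arylamino end of the molecule, which compound 1, compound 2 and compound 3 all share, now has its first reading in this assay: the step is a 1.9-fold higher number from compound 1 to compound 4 (0.27 log units; within the scatter) and so stays within the scatter. On a nitrogen on an aromatic ring, then, 5-chloro-2-methoxyphenyl and 4-chloro-2-methylphenyl cannot be told apart on this read-out, even though the change brings in an oxygen and a hydrogen-bond acceptor and also renumbers the chlorine, so this single step covers two differences at once. No accompanying evidence bears on this step, and no cause can be assigned to it.

The compounds shown leave open how the methyl-to-methoxy exchange and the renumbered chlorine would each read alone, and whether the 5-chloro-2-methoxyphenyl group would read the same alongside the 4-chlorophenyl of compound 2 or the 2,6-dichlorophenyl of compound 3. They also leave open how this ring would read with an ethoxy group in place of the methoxy, or with an amine or a carboxylic acid on it.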